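A few compounds are considered here, and "the series" means these few. Any claim that something is new, unique, unknown or untested is made for them only; others in the source may bear on it.

Measured so far:
Compound 1, `COc1ccc(-c2ocnc2-c2cc(OC)c(OC)c(OC)c2)cc1S`: 4440 nM
Compound 2, `COc1cc(-c2ocnc2-c2cc(OC)c(OC)c(OC)c2)ccc1SC`: 645 nM
Compound 3, `COc1ccc(-c2ocnc2-c2cc(Br)c(OC)c(OC)c2)cc1OC`: 70 nM

The three compounds share a common core and were tested in a functional assay on HeLa cells (Homo sapiens) for cytotoxicity, read by MTT assay, with a stated time of 48 h; on this read-out higher numbers stand for weaker inhibition and lower numbers for stronger inhibition. In this assay compound 1 gives 4440 nM, compound 2 gives 645 nM and compound 3 gives 70 nM. Compound 2 thus stands second highest of the three numbers: its nearest neighbour is compound 1, whose number is higher by a margin beyond the usual scatter, while compound 3 lies furthest from it, lower by a margin that is also beyond the scatter. No two of the measured compounds differ in only one place, so none of these gaps can be tied to a single structural change.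

The unmeasured compound 4, `COc1cc(-c2ncoc2-c2cc(Br)c(SC)c(OC)c2)cc(OC)c1OC`, is built from compound 2 by one change: bromo in place of hydrogen on an aromatic carbon. Among the compounds with values here, no measured pair shows this change on its own, so what it does to the number is open. Compound 3, which also carries a bromo group, shows the lowest number of the three, but its bromo sits in a different place, and that is all its value can say here. A moderate step downward from compound 2, larger than the scatter, is what is expected, written as a 2.2-fold lower number from compound 2 to compound 4 (0.33 log units; beyond the scatter). For compound 4 the estimated result in this assay is 300 nM, with a range from 80 nM to 1200 nM.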

Compound 4, half-maximal inhibitory concentration: > 20000 nM
Compound 4 gave a limit, no number; the forecaster's own chance of this, stated with the estimate: 3%; middle value at least 66-fold (1.82 log units) from the limit.
By their numbers in this assay, from the lowest: compound 3; then compound 2; then compound 1. At a limit, above all of these: compound 4.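

In this assay, bromo in place of hydrogen on an aromatic carbon, ortho to a methylsulfanyl group, gives an at least 31-fold higher number from compound 2 to compound 4 (1.49 log units; beyond the scatter). Within the data shown here, this is the first step tied to a single change, and it shows that this position is far from indifferent to substitution: here a single bromo group goes with a much weaker result, and the low number of compound 3, whose bromo sits in a different place, cannot be carried over to it. Compound 4 gives a limit and not a number, so the step marks only the smallest loss that fits the data, and its true size stays unknown: the limit of > 20000 nM in this assay, at which 1 of the 4 values shown sits.

As far as these compounds go, whether a fluoro group, a methyl group or an amine on this same aromatic carbon would go with a similar loss stays open, as does whether bromo would have the same effect in a compound without the methylsulfanyl group. The compounds shown also give no account of what lies behind the step, so it stands as an observation about this one pair.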